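From 2-chlorophenyl to 4-methylphenyl in compound 4

A few compounds are considered here, and "the series" means these few. Any claim that something is new, unique, unknown or untested is made for them only; others in the source may bear on it.

In a functional assay on K562 cells (Homo sapiens) for inhibition, read by trypan blue exclusion, with a stated time of 48 h (a higher number here means a weaker inhibitor, a lower number a stronger inhibitor), compound 3 `NC(=O)c1cc(I)ccc1NC(=O)/C=C/c1ccccc1Cl` gives 1200 nM, the higher of the two actual numbers available. Compound 2 `NC(=O)c1cc(I)ccc1NC(=O)/C=C/c1ccccc1` gives 570 nM. Compound 4 `Cc1ccc(/C=C/C(=O)Nc2ccc(I)cc2C(N)=O)cc1` has 4-methylphenyl in place of 2-chlorophenyl on a double-bonded chain carbon bound to a double-bonded chain carbon. Going by the values given here, the one measured step bearing on this change is a 2.1-fold higher number from compound 2 to compound 3 (0.32 log units; beyond the scatter), a modest one. Compound 1 `Cc1ccc(/C=C/C(=O)Nc2ccc(Br)cc2C(N)=O)cc1`, which also carries 4-methylphenyl, gives only a limit of the assay, > 10000 nM, so the expectation in this assay leans towards a higher number. The expected change is small, a 1.5-fold higher number from compound 3 to compound 4 (0.18 log units; within the scatter). For compound 4 the estimated value is 1800 nM, within an expected range of 450 nM to 9000 nM.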

Compound 4, half-maximal inhibitory concentration: > 10000 nM
Compound 4: only a limit was reported (the forecaster's own chance of this, stated with the estimate: 15%); at least 5.5-fold (0.74 log units) between middle value and limit.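

In this assay compound 4 gives only a limit of the assay, not a number, and compound 1 stands at that same limit: the limit of > 10000 nM in this assay, at which 2 of the 4 values shown sit. Adding a methyl group brings an at least 17-fold higher number from compound 2 to compound 4 (1.24 log units; beyond the scatter), a larger step than the one chloro brought, a 2.1-fold higher number from compound 2 to compound 3 (0.32 log units; beyond the scatter). Exchanging 2-chlorophenyl for 4-methylphenyl brings an at least 8.3-fold higher number from compound 3 to compound 4 (0.92 log units; beyond the scatter), so on this chain carbon the 4-methylphenyl group costs more than the 2-chlorophenyl group.

The step between compound 1 and compound 4 cannot be read, so iodo and bromo remain unseparated alongside 4-methylphenyl. Going by these compounds, whether 4-methoxyphenyl or 4-fluorophenyl at this place would give a number rather than a limit stays open.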